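The source may report more compounds than this note shows. Statements on the series, on what has been measured and on what is new or still open speak of the compounds shown alone.

Compound 1, `C#CCSc1nc(Nc2ccc(Cl)cc2)c(C#N)c(-c2ccccc2)n1`: > 128000 nM (a limit, not a number)
Compound 2, `N#Cc1c(Nc2cccc(C(F)(F)F)c2)nc(SCc2cn(Cc3ccccc3Cl)nn2)nc1-c1ccccc1`: 22800 nM
Compound 3, `N#Cc1c(Nc2ccccc2Cl)nc(SCc2cn(Cc3ccccc3Cl)nn2)nc1-c1ccccc1`: 4640 nM

Of the compounds shown here, three sharing one core have been tested in a functional assay on MGC-803 cells (Homo sapiens) for inhibition, read by MTT assay, with a stated time of 72 h; a lower number here means a stronger inhibitor, a higher number a weaker inhibitor. Compound 1 reaches only the assay limit, > 128000 nM. Within the data shown here, compound 1 is thus the one value sitting at the limit of > 128000 nM in this assay, at which 1 of the 3 values shown sits. Between the two numbered values, compound 3 gives the lower number, and the gap to compound 2 is beyond the scatter: a 4.9-fold lower number from compound 2 to compound 3 (0.69 log units; beyond the scatter), the only single-point step so far, where 2-chlorophenyl replaces 3-(trifluoromethyl)phenyl on the nitrogen on the aromatic ring.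

Compound 4, `N#Cc1c(Nc2cccc(Cl)c2)nc(SCc2cn(Cc3ccccc3Cl)nn2)nc1-c1ccccc1`, has not been measured. It differs from compound 3 by 3-chlorophenyl in place of 2-chlorophenyl on a nitrogen on an aromatic ring, so the chlorine moves on the same phenyl while all atoms stay the same. Among the measured compounds shown here, no measured step covers exactly this move. For the measured compounds named here, the one step that bears on it, from compound 2 to compound 3, shows that the substitution pattern of this phenyl changes the number by a modest, scatter-exceeding amount, and that a 3-substituted phenyl gave the higher number. Compound 4, carrying a 3-substituted phenyl again, is therefore expected to give a somewhat higher number than compound 3, a 2.2-fold higher number from compound 3 to compound 4 (0.33 log units; beyond the scatter). Compound 4 is estimated at 10000 nM, with a range from 3000 nM to 35000 nM.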

Compound 4, half-maximal inhibitory concentration: 15800 nM
Compound 4: middle estimate off by 1.6-fold (0.20 log units), on the low side, and the stated range covers the measured number.
By their numbers in this assay, from the lowest: compound 3; then compounds 4 and 2 (each within the scatter of the next). At a limit, above all of these: compound 1.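

With the atoms unchanged, moving from 2-chlorophenyl to 3-chlorophenyl on the nitrogen gives a 3.4-fold higher number from compound 3 to compound 4 (0.53 log units; beyond the scatter) in this assay, so the place of the chlorine on this phenyl alone changes the number by more than the scatter. The earlier step, a 4.9-fold lower number from compound 2 to compound 3 (0.69 log units; beyond the scatter), changed both the group and its place and could not separate the two. Exchanging the group while keeping its place, with chloro in place of trifluoromethyl on an aromatic carbon, gives a 1.4-fold lower number from compound 2 to compound 4 (0.16 log units; within the scatter) and does not separate these two compounds, so among compounds 2, 3 and 4 the lower number goes with 2-chlorophenyl alone, and the two 3-substituted phenyl compounds stand together.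

The compounds shown leave open whether other groups on this phenyl, such as 2-fluorophenyl or 2-methoxyphenyl, would keep the lower number of compound 3 or whether it belongs to the chlorine itself. Nothing measured here speaks to why the place of the chlorine changes the number.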